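Tetrazole in place of nitrile on the alkoxy chain

This account rests on a few compounds, and the source may have more. Where it says the series, first, only, none or still open, it means among the compounds named here.

Compound 1 `C=CCc1cc(C(C)=O)c(O)cc1OCCCCCCCC#N` gives 52% in an assay on isolated protein for binding affinity to leukotriene B4 receptor 1 (Homo sapiens), tested at 1 uM (a higher number here means more inhibition at the concentration tested (going by the name of the read-out), a lower number less inhibition), and compound 2 `CCc1cc(C(C)=O)c(O)cc1OCCCCC(C)(C)C#N` gives 30% in this assay, the lower of the two numbers shown, a gap that lies beyond the scatter; no single-change step joins them. Compound 3 `CCc1cc(C(C)=O)c(O)cc1OCCCCc1nnn[nH]1` differs from compound 2 by 1H-tetrazol-5-yl in place of 1-cyano-1-methylethyl on a saturated chain carbon, four bonds along the chain from an oxygen on an aromatic ring. For the measured compounds named here, no comparable step has been measured, so an expectation for compound 3 can rest only on the value of compound 2 in this assay, 30%, and a step of a number 5 percentage points higher from compound 2 to compound 3 (within the scatter) is expected, within the scatter. Compound 3 is therefore estimated at 35%, with a range from 10% to 65%.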

Compound 3, a percentage reported as inhibition, at one concentration (the size of the read-out at that concentration, not a potency): 19%
The estimate for compound 3 lay 16 percentage points above the measured number; measured number inside the range.
By their numbers in this assay, from the lowest: compound 3; then compound 2; then compound 1.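

In this assay, for the compounds shown here, the change to 1H-tetrazol-5-yl from 1-cyano-1-methylethyl, on a saturated chain carbon, four bonds along the chain from an oxygen on an aromatic ring, gives the first readable step at this position: a number 11 percentage points lower from compound 2 to compound 3 (beyond the scatter). The position therefore responds to this swap, though both groups have the same heavy-atom count. Nothing on hand accounts for the step.

On these data alone, whether a carboxylic acid or a primary amide at this position would read like the tetrazole remains open. So does whether a longer chain carrying the tetrazole would recover the read-out.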